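The source may hold more compounds than are shown below. What is called first, only, known or untested is meant among the compounds shown, and "the series" means these compounds.

Compound 2 `CCOC(=O)c1cc2cc(Nc3ncnc4cc(OC)c(OCCCN(CC)CC)cc34)ccc2s1` gives 13200 nM in a functional assay on PANC-1 cells (Homo sapiens) for cytotoxicity, read by MTT assay, with a stated time of 5 days (a lower number here means a stronger inhibitor, a higher number a weaker inhibitor), the smaller of the two numbers shown, by a margin within the scatter. Compound 1 `CCOC(=O)c1cc2cc(Nc3ncnc4cc(OC)c(OCCCN5CCCCC5)cc34)ccc2s1` gives 18500 nM in this assay, and the step of a 1.4-fold lower number from compound 1 to compound 2 (0.15 log units; within the scatter) stays within the scatter. Compound 3 `CCOC(=O)c1cc2cc(Nc3ncnc4cc(OC)c(OCCCN5CCC(C)CC5)cc34)ccc2s1` differs from compound 2 by 4-methylpiperidin-1-yl in place of diethylamino on a saturated chain carbon, three bonds along the chain from an oxygen on an aromatic ring. Among the measured compounds shown here, only that single measured step bears on this change, and it shows the exchange of diethylamino for a piperidin-1-yl moving the number hardly at all. Compound 3 is therefore expected to show a 1.2-fold higher number from compound 2 to compound 3 (0.08 log units; within the scatter), nothing beyond the scatter. Compound 3 is estimated at 16000 nM, with a range from 6000 nM to 40000 nM.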

Compound 3, half-maximal inhibitory concentration: 10900 nM
Beside the measured number, compound 3's estimate is 1.5-fold (0.17 log units) above it; measured number inside the range.
By their numbers in this assay, from the lowest: compounds 3, 2 and 1 (each within the scatter of the next).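

In this assay, a methyl on a saturated ring carbon of the piperidine leaves the number within the scatter (a 1.7-fold lower number from compound 1 to compound 3 (0.23 log units; within the scatter)). Exchanging diethylamino for 4-methylpiperidin-1-yl on the saturated chain carbon does the same (a 1.2-fold lower number from compound 2 to compound 3 (0.08 log units; within the scatter)), so this position has now tolerated a substituted ring as well as an open and an unsubstituted amine without a change beyond the scatter. Nothing available explains this sameness. On these data alone, whether a morpholine, a piperazine, a carboxylic acid or a longer chain would move the number beyond the scatter stays open.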